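The compounds below may be only part of what the source reports. "The series", "measured", "known", "first", "only" and "open" are said of these compounds alone.

compound 1 `C#CCOC(=O)NN=C1C(Cl)=C(Cl)C(Cl)=C1Cl`: "not determined" (no result reported)
compound 2 `ClC1=C(Cl)C(Cl)=C(Cl)C1=NN(c1ccccc1)c1ccccc1`: > 3000 nM
compound 3 `Cc1cccc(NN=C2C(Cl)=C(Cl)C(Cl)=C2Cl)c1`: > 3000 nM

These three compounds were tested for their ability to kill cultured cells in a functional assay on MM1.S cells (Homo sapiens) for cytotoxicity, read by MTT assay, with a stated time of 48 h; a lower number here means a stronger inhibitor, a higher number a weaker inhibitor. In this assay compound 1 gives "not determined" (no result reported), so the starting point of this step has no number at all. Compound 2 gives > 3000 nM, which is a limit of the assay and not a number. Compound 3 gives > 3000 nM, which is also a limit and not a number. Within the data shown here, the series therefore offers no exact potency to build on, and no measured step between two compounds.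

The next structure is compound 4 `CC(C)(C)C(=O)NN=C1C(Cl)=C(Cl)C(Cl)=C1Cl`, which keeps the core of compound 1. It has tert-butyl in place of propargyloxy on a carbonyl carbon.

With no number for compound 1, the size of this step cannot be worked out from the data. The expectation in this assay is therefore no step beyond the scatter, in either direction. Among the measured compounds shown here, a weak result is expected for compound 4 because the limit of > 3000 nM in this assay, at which 2 of the 3 values shown sit, is the only guide available, and the assay may again report just a limit. If a number is reported, compound 4 is expected at 2500 nM, with an estimated range from 500 nM to 10000 nM.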

Compound 4, half-maximal inhibitory concentration: 2000 nM
Beside the measured number, compound 4's estimate is 1.3-fold (0.10 log units) above it; the range from low to high includes it.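

Compound 4 gives 2000 nM in this assay, the only exact number among the compounds shown, but compound 1 has no reported result, so no step between compound 1 and compound 4 can be read. The compounds shown leave open what exchanging propargyloxy for tert-butyl on the carbonyl carbon does to potency.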